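A few compounds are considered here, and "the series" means these few. Any claim that something is new, unique, unknown or untested is made for them only; others in the source may bear on it.

Of the compounds shown here, three have so far been tested in a functional assay on CCRF-CEM cells (Homo sapiens) for inhibition, read by sulforhodamine B assay, with a stated time of 48 h; on this read-out lower numbers stand for stronger inhibition of growth and higher numbers for weaker inhibition of growth. Compound 1 `N=C(N)c1ccc(-c2ccc(-c3cncc4ccccc34)s2)s1` gives 360 nM. Compound 2 `N=C(N)c1ccc(-c2ccc(-c3ccc(F)cc3)o2)o1` gives 1840 nM. Compound 3 `N=C(N)c1ccc(-c2ccc(-c3ccc(Cl)cc3)s2)s1` gives 1840 nM. Compound 2 therefore stands level with compound 3 at the digits shown, a gap within the usual scatter, and the two together hold the highest numbers of the three; the compound furthest from compound 2 is compound 1, whose number is lower by an amount beyond the scatter.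

Compound 4 `COc1ccc(-c2ccc(-c3ccc(C(=N)N)o3)o2)cc1` has not yet been measured. It differs from compound 2 in a single place: methoxy in place of fluoro on an aromatic carbon. Among the compounds with values here, no measured pair shows this exact exchange, so there is no directly observed step to lean on. With nothing in the measured set pointing to a large shift, the change from compound 2 to compound 4 is expected to stay within the scatter, in no firm direction. Compound 4 is accordingly estimated at 1500 nM in this assay, within a range from 500 nM to 5000 nM. That estimate corresponds to a step of a 1.2-fold lower number from compound 2 to compound 4 (0.09 log units; within the scatter).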

Compound 4, concentration for 50% growth inhibition: 1840 nM
Compound 4: the middle estimate sits 1.2-fold (0.09 log units) below what was measured; measured number inside the range.
By their numbers in this assay, from the lowest: compound 1; then compounds 2, 3 and 4 (each within the scatter of the next).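

In this assay, methoxy in place of fluoro on an aromatic carbon, para to a large group, gives no change at the digits printed from compound 2 to compound 4 (within the scatter). Within the data shown here, this is the first single-place exchange in the set, and it shows that this position accepts methoxy, with 2 heavy atoms and 1 hydrogen-bond acceptor, in place of fluoro, with 1 heavy atom and none, without any shift beyond the scatter. No other measurement bears on why the number holds, so the step stands as a plain observation.

Going by these compounds, whether an amine, a carboxylic acid or a longer chain such as butoxy would also leave the number unchanged at this place stays open. So does whether methoxy in place of fluoro would read the same on a different core, such as the core of compound 1.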